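This account rests on a few compounds, and the source may have more. Where it says the series, first, only, none or still open, it means among the compounds named here.

Measured compounds in a functional assay on MCF7 cells (Homo sapiens) for inhibition, read by sulforhodamine B assay; on this read-out lower numbers stand for stronger inhibition and higher numbers for weaker inhibition:
- Compound 1 `O=C1C=C(Nc2ccc(I)cc2)C(=O)c2c1nc1n2[C@H]2OC[C@@H](O)[C@H]2OC1`: 2230 nM
- Compound 2 `Cc1ccc(NC2=CC(=O)c3nc4n(c3C2=O)[C@H]2OC[C@@H](O)[C@H]2OC4)cc1C`: 2080 nM
- Compound 3 `O=C1C=C(Nc2ccccc2)C(=O)c2c1nc1n2[C@H]2OC[C@@H](O)[C@H]2OC1`: a limit, > 4000 nM

Compound 3 sits at the limit of > 4000 nM in this assay, at which 1 of the 3 values shown sits, so for it only a limit is known and no number. The two steps that lead to it are an at least 1.7-fold higher number from compound 1 to compound 3 (0.25 log units; that floor lies within the scatter) and an at least 1.9-fold higher number from compound 2 to compound 3 (0.28 log units; that floor lies within the scatter); both floors are within the scatter, so compound 3 cannot be told apart from compound 1 or compound 2 on the numbers shown. Compound 4 `O=C1C=C(NC2CCCCC2)C(=O)c2c1nc1n2[C@H]2OC[C@@H](O)[C@H]2OC1` differs from compound 3 by cyclohexyl in place of phenyl on an amine nitrogen. Within the data shown here, none of the measured steps bears directly on this change: each of them alters what sits on the phenyl, and none exchanges the phenyl itself for a non-aromatic ring. The step between compound 1 and compound 2, a 1.1-fold lower number from compound 1 to compound 2 (0.03 log units; within the scatter), shows that such changes on the phenyl move the number little. With no guide to direction, the expected step is a step that the limit leaves unreadable from compound 3 to compound 4, that is, nothing beyond the scatter. Compound 4 is therefore expected to give about 5000 nM, within 2000 nM to 15000 nM, most likely again reported as a limit.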

Compound 4, half-maximal inhibitory concentration: > 8000 nM
Compound 4: only a limit was reported; the forecaster's own chance of this, stated with the estimate: 65%; at least 1.6-fold (0.20 log units) between middle value and limit.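

In this assay, compound 4 is known only as a limit, > 8000 nM. Even so, cyclohexyl in place of 3,4-dimethylphenyl gives an at least 3.8-fold higher number from compound 2 to compound 4 (0.58 log units; beyond the scatter), and cyclohexyl in place of 4-iodophenyl gives an at least 3.5-fold higher number from compound 1 to compound 4 (0.55 log units; beyond the scatter), so at this amine nitrogen the non-aromatic ring gives a clearly weaker result than either of these two substituted phenyl rings. The direct exchange of phenyl for cyclohexyl cannot be read, as compound 3 and compound 4 both stand as limits, so the plain phenyl of compound 3 does not show that an aromatic ring alone is enough.

As far as these compounds go, it remains open whether the ring's aromatic character matters or only the substituents on it. An open hexyl chain, a cyclopentyl ring or a benzyl group on the same nitrogen could help separate these possibilities.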